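The source may hold more compounds than are shown below. What is called first, only, known or untested is meant among the compounds shown, and "the series" means these compounds.

In a toxicity assay on HeLa cells (Homo sapiens) for cytotoxicity, read by colorimetric assay, with a stated time of 72 h (on this read-out higher numbers stand for lower toxicity in this test and lower numbers for higher toxicity in this test), compound 1 `CN1CCC(CCCC2CCN(c3nc(=O)c4cc(C(F)(F)F)cc([N+](=O)[O-])c4s3)CC2)CC1` gives 20100 nM, and compound 2 `O=c1nc(N2CC[C@](O)(COc3ccc(F)cc3)[C@@H](O)C2)sc2c([N+](=O)[O-])cc(C(F)(F)F)cc12` gives 34300 nM. Compound 3 `N#Cc1ccccc1N1CCN(c2nc(=O)c3cc(C(F)(F)F)cc([N+](=O)[O-])c3s2)CC1` is reported only as a limit of the assay, > 108000 nM, and not as a number. It is the only one of the three at this limit. Compound 4 `O=C(CN1CCN(c2nc(=O)c3cc(C(F)(F)F)cc([N+](=O)[O-])c3s2)CC1)Nc1ccccn1` carries ((pyridin-2-yl)carbamoyl)methyl in place of 2-cyanophenyl on an amine nitrogen in a ring. Going by the values given here, no measured pair shows what such a change does. An expected move of an at least 1.8-fold lower number from compound 3 to compound 4 (0.25 log units; that floor lies within the scatter) points toward lower numbers and higher toxicity, though the read-out may again stop at a limit. For compound 4 the estimate is 60000 nM, with an expected range of 20000 nM to 108000 nM.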

Compound 4, half-maximal cytotoxic concentration: 44500 nM
Beside the measured number, compound 4's estimate is 1.3-fold (0.13 log units) above it; the measured number falls inside the stated range.
By their numbers in this assay, from the lowest: compounds 1, 2 and 4 (each within the scatter of the next, the first and the last beyond it). At a limit, above all of these: compound 3.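

In this assay, ((pyridin-2-yl)carbamoyl)methyl in place of 2-cyanophenyl on this amine nitrogen in a ring gives an at least 2.4-fold lower number from compound 3 to compound 4 (0.38 log units; beyond the scatter). This is the first pair among the compounds shown that differs in one place, and it shows that the group on this nitrogen can move the read-out. The step gives only a minimum size, since it starts from a limit of the assay: the limit of > 108000 nM in this assay, at which 1 of the 4 values shown sits.

Which part of the entering group carries the step remains open, as the ring, carbonyl and amide hydrogen all change together. From the compounds shown here alone, it is also open how a plain phenyl or a carboxylic acid on this nitrogen would read.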